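Methylsulfanyl for methoxycarbonyl on the shared core

This account rests on a few compounds, and the source may have more. Where it says the series, first, only, none or still open, it means among the compounds named here.

Among the compounds with values here, compound 2 `COC(=O)c1cnc(C(=O)CCc2ccc(-c3ccccc3)cc2)o1` gives 1.5 nM in an assay for inhibition of Fatty-acid amide hydrolase 1 (Rattus norvegicus) (on this read-out higher numbers stand for weaker inhibition and lower numbers for stronger inhibition), the lowest of the two numbers measured so far. Compound 1 `O=C(O)c1cc(-c2cnc(C(=O)CCc3ccc(-c4ccccc4)cc3)o2)ccn1` gives 50 nM in this assay; the step of a 33-fold lower number from compound 1 to compound 2 (1.52 log units; beyond the scatter) shows that the group on this carbon of the five-membered aromatic ring with 1 nitrogen and 1 oxygen moves the number strongly. Compound 3 `CSc1cnc(C(=O)CCc2ccc(-c3ccccc3)cc2)o1` differs from compound 2 by methylsulfanyl in place of methoxycarbonyl on an aromatic carbon. Within the data shown here, no measured step covers an exchange of methoxycarbonyl for methylsulfanyl; the one step at this place, from 2-carboxypyridin-4-yl to methoxycarbonyl, was large, and it shows only that the position matters, not in which direction a methylsulfanyl group will move the number. Compound 2 stands at the low end of the two numbers with 1.5 nM, so a rise beyond the scatter in this assay is expected, of moderate size and with wide uncertainty. For compound 3 the expected value is 10 nM, between 2 nM and 60 nM. This expectation means a step of a 6.7-fold higher number from compound 2 to compound 3 (0.82 log units; beyond the scatter).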

Compound 3, inhibition constant: 3 nM
Compound 3: the middle estimate sits 3.3-fold (0.52 log units) above what was measured; the range from low to high includes it.
By their numbers in this assay, from the lowest: compounds 2 and 3 (each within the scatter of the next); then compound 1.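

In this assay, the exchange on this aromatic carbon next to the ring oxygen gives a 2.0-fold higher number from compound 2 to compound 3 (0.30 log units; within the scatter): methylsulfanyl, with 2 heavy atoms and 1 hydrogen-bond acceptor, cannot be told apart from methoxycarbonyl, with 4 heavy atoms and 2 hydrogen-bond acceptors, so the low number at this place does not depend on the carbonyl of methoxycarbonyl. The large gap to 2-carboxypyridin-4-yl now appears with a second group, as a 17-fold lower number from compound 1 to compound 3 (1.22 log units; beyond the scatter), and therefore does not belong to methoxycarbonyl alone. No measured evidence is available to explain either step.

The compounds shown leave open whether the higher number of compound 1 goes with the pyridine ring or with its carboxylic acid, which a plain pyridin-4-yl group or a methyl ester on the same ring would separate. Going by these compounds, it is also open how far this position tolerates other groups, such as an amine, a longer chain like butylsulfanyl, or a carboxylic acid placed directly on the ring carbon.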